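Fluoro for Chloro: From Compound 2 to Compound 3

This account rests on a few compounds, and the source may have more. Where it says the series, first, only, none or still open, it means among the compounds named here.

For the measured compounds named here, compound 2 `CC(c1ccc(-c2ccccc2)c(F)c1)c1nnc2n1N=C(c1ccc(Cl)cc1)CS2` is one of two compounds measured in a functional assay on Hep 3B2 cells (Homo sapiens) for inhibition, read by sulforhodamine B assay, with a stated time of 72 h; a higher number here means a weaker inhibitor, a lower number a stronger inhibitor. In this assay compound 2 gives 3800 nM, the lowest of the two numbers. The other, compound 1 `Cc1ccc(C2=Nn3c(nnc3C(C)c3ccc(CC(C)C)cc3)SC2)cc1`, gives 5300 nM in this assay; the two values lie within the scatter of each other, so no order between them can be read.

The step considered here leads to compound 3 `CC(c1ccc(-c2ccccc2)c(F)c1)c1nnc2n1N=C(c1ccc(F)cc1)CS2`, which differs from compound 2 in one place: fluoro in place of chloro on an aromatic carbon. Read one bond further out, the change is 4-chlorophenyl to 4-fluorophenyl. Going by the values given here, no pair of measured compounds shows this exchange, so there is nothing in the data to size it directly. The step from compound 2 to compound 3 in this assay is expected to be small, a 1.3-fold higher number from compound 2 to compound 3 (0.12 log units; within the scatter), quite possibly none beyond the scatter, with a slight lean towards a higher number. Compound 3 is therefore estimated at 5000 nM in this assay, with a range from 2000 nM to 12000 nM.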

Compound 3, half-maximal inhibitory concentration: 2600 nM
For compound 3 the middle estimate is 1.9-fold (0.28 log units) above the measured one; the range from low to high includes it.
By their numbers in this assay, from the lowest: compounds 3, 2 and 1 (each within the scatter of the next, the first and the last beyond it).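

For the compounds shown here, with this result, the exchange of chloro for fluoro on the aromatic carbon, para to a large group, has a measured size for the first time: in this assay it is a 1.5-fold lower number from compound 2 to compound 3 (0.16 log units; within the scatter), so the two halogens cannot be told apart at this position. The earlier compounds shown here could not show this, as compound 1 and compound 2 differ in more than one place and their values give no reading of any single change. Nothing available explains this result or bears on it beyond the numbers themselves.

Still open, as far as these compounds go, is whether a larger change at this position, such as a methoxy group, an amine or a carboxylic acid in place of the halogen, would give a step beyond the scatter in this assay. Going by these compounds alone, also open is whether the exchange of chloro for fluoro would give a step of similar size if the rest of the molecule carried other groups, since this single pair is the only reading of it.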